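This account rests on a few compounds, and the source may have more. Where it says the series, first, only, none or still open, it means among the compounds named here.

Measured so far in an ADME assay on HepG2 cells (Homo sapiens) for cytotoxicity, read by MTT assay, with a stated time of 72 h (a higher number here means that more compound is tolerated, a lower number that less compound is tolerated), and all of them limits, not numbers:
compound 1 `COc1ccc(C#Cc2cc(Cl)cn3c([N+](=O)[O-])c(CS(=O)(=O)c4ccccc4)nc23)cc1` gives > 3900 nM
compound 2 `O=[N+]([O-])c1c(CS(=O)(=O)c2ccccc2)nc2c(C#Cc3ccc(F)cc3)cc(Cl)cn12` gives > 3900 nM
compound 3 `O=[N+]([O-])c1c(CS(=O)(=O)c2ccccc2)nc2c(C#Cc3cccs3)cc(Cl)cn12` gives > 3900 nM

Compound 3 gives > 3900 nM as a limit only. The series stands at the limit of > 3900 nM in this assay, at which 3 of the 3 values shown sit, and so gives compound 3 no rank.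

Going to compound 4 `O=[N+]([O-])c1c(CS(=O)(=O)c2ccccc2)nc2c(C#CCOc3ccccc3)cc(Cl)cn12` puts phenoxymethyl in place of thiophen-2-yl on a triple-bonded carbon. Both a step that the two limits leave unreadable from compound 1 to compound 3 and also a step that the two limits leave unreadable from compound 2 to compound 3 change the same place and neither has a readable size. In this assay no step beyond the scatter is expected, the estimated move being a step that the limit leaves unreadable from compound 3 to compound 4 and a further limit being likely. Compound 4 is expected at 4500 nM with an estimated range from 2000 nM to 10000 nM here.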

Compound 4, half-maximal cytotoxic concentration: 8400 nM
The estimate for compound 4 lay 1.9-fold (0.27 log units) below the measured number; the measured number falls inside the stated range.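

Going by these compounds alone, no step from compound 1, compound 2 or compound 3 to compound 4 can be read in this assay, since the first three values are limits only: the limit of > 3900 nM in this assay, at which 3 of the 4 values shown sit. On these data alone, whether phenoxymethyl on the triple-bonded carbon differs at all from 4-methoxyphenyl, 4-fluorophenyl or thiophen-2-yl remains open.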